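Urea tail variation in the sulfonamide series

The source may hold more compounds than are shown below. What is called first, only, known or untested is meant among the compounds shown, and "the series" means these compounds.

Measured so far, in a functional assay on HCT-116 cells (Homo sapiens) for cytotoxicity, read by MTT assay, with a stated time of 72 h; a higher number here means a weaker inhibitor, a lower number a stronger inhibitor:
compound 1 `CNC(=O)Nc1nc2ccc(-c3cnc(OC)c(NS(=O)(=O)c4ccc(F)cc4)c3)cn2n1` gives 180 nM
compound 2 `COc1ncc(-c2ccc3nc(NC(=O)NCCN(C)C)nn3c2)cc1NS(=O)(=O)c1ccc(F)cc1` gives 220 nM

Among the measured compounds shown here, compound 2 holds the highest of the two numbers in this assay, its only neighbour being compound 1 with a 1.2-fold higher number from compound 1 to compound 2 (0.09 log units; within the scatter), so the two are indistinguishable. That step replaced hydrogen with (dimethylamino)methyl on the saturated chain carbon bound to the amide-type nitrogen and changed nothing beyond the scatter.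

Compound 3 `COc1ncc(-c2ccc3nc(NC(=O)NCCN4CCCCC4)nn3c2)cc1NS(=O)(=O)c1ccc(F)cc1` carries piperidin-1-yl in place of dimethylamino on a saturated chain carbon, two bonds along the chain from an amide-type nitrogen. For the measured compounds named here, the only comparable step is the one from compound 1 to compound 2, which added the basic chain and was itself within the scatter. No shown step bears directly on enlarging the terminal amine into a ring, so no movement beyond the scatter is expected in this assay. Compound 3 is therefore expected to give 230 nM, within 110 nM to 480 nM, a step of a 1.0-fold higher number from compound 2 to compound 3 (0.02 log units; within the scatter).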

Compound 3, half-maximal inhibitory concentration: 150 nM
The estimate for compound 3 lay 1.5-fold (0.19 log units) above the measured number, and the stated range covers the measured number.
By their numbers in this assay, from the lowest: compounds 3, 1 and 2 (each within the scatter of the next).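

In this assay, piperidin-1-yl in place of dimethylamino gives a 1.5-fold lower number from compound 2 to compound 3 (0.17 log units; within the scatter), so this place on the chain accepts a six-membered non-aromatic ring with no movement beyond the scatter. The full (piperidin-1-yl)methyl change on the hydrogen-bearing chain carbon gives a 1.2-fold lower number from compound 1 to compound 3 (0.08 log units; within the scatter), which places this ring tail, like the open dimethylamino tail, within the scatter of the shorter urea. No measurement shown offers an explanation for this flat response to the tail.

Still open, as far as these compounds go, is whether a morpholine ring, a carboxylic acid or a longer chain in the same place would also stay within the scatter. The tails shown also leave open which change at this position, if any, would produce a step beyond it.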